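This account rests on a few compounds, and the source may have more. Where it says the series, first, only, none or still open, it means among the compounds named here.

In an ADME assay on microsomes from liver (Mus musculus, strain CD-1) for metabolic stability, read by LC-MS, tested at 2 uM (a lower number here means that the compound disappears faster, a higher number that the compound lasts longer), three compounds sharing one core have been measured, and their values lie close together. Compound 1 (`CN1CCC(CNS(=O)(=O)c2ccccc2Nc2cc(-c3ccc4ccn(C)c4c3)c3nccnc3c2)C1`) gives 0.633 h, compound 2 (`Cn1ccc2ccc(-c3cc(Nc4ccccc4S(N)(=O)=O)cc4nccnc34)cc21`) gives 0.5 h, and compound 3 (`Cn1ccc2ccc(-c3cc(Nc4ccccc4S(=O)(=O)Nc4cncnc4)cc4nccnc34)cc21`) gives 0.683 h. Compound 3 therefore stands within the scatter of both others. The next structure, compound 4 (`CN1CCCC(NS(=O)(=O)c2ccccc2Nc2cc(-c3ccc4ccn(C)c4c3)c3nccnc3c2)C1`), carries 1-methylpiperidin-3-yl in place of pyrimidin-5-yl on a sulfonamide nitrogen. Going by the values given here, three measured steps bear on this change, all at that same place. The most telling is a 1.1-fold higher number from compound 1 to compound 3 (0.03 log units; within the scatter), which exchanges (1-methylpyrrolidin-3-yl)methyl for pyrimidin-5-yl, the group that leaves here. The other two, a 1.3-fold lower number from compound 1 to compound 2 (0.10 log units; within the scatter) and a 1.4-fold higher number from compound 2 to compound 3 (0.14 log units; within the scatter), also stay within the scatter. None of the three gives a reason to expect a real shift, although none tests 1-methylpiperidin-3-yl itself. The expected change is therefore no larger than the scatter, and the estimate is a 1.1-fold lower number from compound 3 to compound 4 (0.06 log units; within the scatter). For compound 4, the expected half-life is 0.6 h, with an estimated range of 0.3 h to 1.2 h.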

Compound 4, half-life: 0.483 h
Estimate against measurement, compound 4: 1.2-fold (0.09 log units) above; the measured number falls inside the stated range.
By their numbers in this assay, from the lowest: compounds 4, 2, 1 and 3 (each within the scatter of the next).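

Among the compounds shown, only compound 4 carries 1-methylpiperidin-3-yl on a sulfonamide nitrogen, and in this assay replacing the aromatic pyrimidin-5-yl with this non-aromatic ring gives a 1.4-fold lower number from compound 3 to compound 4 (0.15 log units; within the scatter) and so no real shift. The same group, set against hydrogen, gives a 1.0-fold lower number from compound 2 to compound 4 (0.02 log units; within the scatter) and, set against (1-methylpyrrolidin-3-yl)methyl, gives a 1.3-fold lower number from compound 1 to compound 4 (0.12 log units; within the scatter) so that all four groups at this place now lie within the scatter of one another. No measured information is available to account for these numbers.

As far as these compounds go, whether a carboxylic acid or a longer chain ending in a morpholine on this nitrogen would also leave the half-life unmoved remains open. So does whether a change anywhere else on the shared core would move it.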